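A few compounds are considered here, and "the series" means these few. Any claim that something is new, unique, unknown or untested is made for them only; others in the source may bear on it.

Measured in an ADME assay on L02 cells (Homo sapiens) for cytotoxicity, read by MTT assay, with a stated time of 24 h (on this read-out lower numbers stand for stronger inhibition and higher numbers for weaker inhibition), three compounds are in hand:

Compound 1, `COc1cc(/C=C2\CN(C)C/C(=C\c3ccc(Cl)cc3Cl)C2=O)cc(OC)c1OC`, gives 13400 nM.
Compound 2, `COc1cc(/C=C2\CN(C)C/C(=C\c3ccc(Cl)c(Cl)c3)C2=O)cc(OC)c1OC`, gives 18400 nM.
Compound 3, `CN1C/C(=C\c2cccc([N+](=O)[O-])c2)C(=O)/C(=C/c2ccc(Cl)cc2Cl)C1`, gives 14000 nM.

All three numbers lie within the usual scatter of one another, so no order among them can be claimed. Compound 2 arises from compound 1 by one change, (3,4-dichlorophenyl in place of 2,4-dichlorophenyl on a double-bonded chain carbon bound to a double-bonded ring carbon), and that change gave a 1.4-fold higher number from compound 1 to compound 2 (0.14 log units; within the scatter). Compound 4, `CN1C/C(=C\c2cccc([N+](=O)[O-])c2)C(=O)/C(=C/c2ccc(Cl)c(Cl)c2)C1`, is not yet measured; it arises from compound 3 by the same change, (3,4-dichlorophenyl in place of 2,4-dichlorophenyl on a double-bonded chain carbon bound to a double-bonded ring carbon). The difference between the core of compound 1 and the core of compound 3 is not broken down here. For compound 4 the step expected in this assay is a 1.2-fold higher number from compound 3 to compound 4 (0.08 log units; within the scatter), because the same change earlier gave a 1.4-fold higher number from compound 1 to compound 2 (0.14 log units; within the scatter). Compound 4 is therefore estimated at 17000 nM, most likely between 9000 nM and 32000 nM.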

Compound 4, half-maximal inhibitory concentration: 14800 nM
Estimate against measurement, compound 4: 1.1-fold (0.06 log units) above, within the range that was stated.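

Putting 3,4-dichlorophenyl in place of 2,4-dichlorophenyl gave, in this assay, a 1.1-fold higher number from compound 3 to compound 4 (0.02 log units; within the scatter). Carried from one core to the other, the change shows no difference in its size that can be told from noise: the same change on two cores in this assay, a 1.4-fold higher number (0.14 log units; within the scatter) from compound 1 to compound 2 and a 1.1-fold higher number (0.02 log units; within the scatter) from compound 3 to compound 4, 1.3-fold (0.11 log units) apart, within the scatter of two such steps. For the compounds shown here, both steps lie within the scatter, so this shows only that the change has no detectable effect on either core; it does not show that the same would hold on a third core, or that the two cores would respond alike to a change with a larger step.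

Still open, from the compounds shown here alone, is whether a phenyl ring bearing an amine or a carboxylic acid instead of the two chlorines would move the number beyond the scatter.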